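The compounds below may be only part of what the source reports. "The series", "measured", "known", "first", "only" and "open" are said of these compounds alone.

Compound 1 `OC(c1ccc(Cl)cc1)(c1cncnc1)c1ccccc1F` is one of two compounds with a cytotoxicity read-out in an ADME assay on L6 cells (Rattus norvegicus) for cytotoxicity, read by resazurin assay, with a stated time of 72 h; on this read-out lower numbers stand for stronger inhibition and higher numbers for weaker inhibition. The value of compound 1 in this assay, > 100000 nM, is a limit of the assay and not a number (the limit of > 100000 nM in this assay, at which 1 of the 2 values shown sits). Compound 2 `OC(c1ccc(Cl)cc1)(c1ccc(Br)cc1)c1cncnc1` gives 58700 nM in this assay. Within the data shown here, the one measured step, an at least 1.7-fold lower number from compound 1 to compound 2 (0.23 log units; that floor lies within the scatter), goes with 4-bromophenyl in place of 2-fluorophenyl on a saturated chain carbon bound to two aromatic carbons and an oxygen on a saturated carbon. Compound 3 `OC(c1ccc(Cl)cc1)(c1cccnc1)c1ccccc1F` has not yet been measured in this assay. It differs from compound 1 by pyridin-3-yl in place of pyrimidin-5-yl on a saturated chain carbon bound to two aromatic carbons and an oxygen on a saturated carbon. Among the measured compounds shown here, no measured step touches this position; the step from compound 1 to compound 2 bears on it only in showing how little the pair moves around the limit. No step beyond the scatter is therefore expected in this assay, in either direction, and the expected step is a number no higher from compound 1 to compound 3 (the limit leaves the size open). Compound 3 is estimated at 100000 nM, between 40000 nM and 300000 nM, with a fair chance that this assay again reports only a limit.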

Compound 3, half-maximal inhibitory concentration: > 100000 nM
Compound 3: no number, only a limit; the forecaster's own chance of this, stated with the estimate: 60%; the middle value sits exactly at the limit.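

In this assay no step can be read between compound 1 and compound 3, because both stand at the same limit and neither gives a number: the limit of > 100000 nM in this assay, at which 2 of the 3 values shown sit. The compounds shown leave open whether pyridin-3-yl in place of pyrimidin-5-yl shifts this cytotoxicity read-out at all, and in which direction.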